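Moving the bromine from compound 2 to compound 3

The compounds below may be only part of what the source reports. "The series", "measured", "known", "first", "only" and "open" are said of these compounds alone.

In an ADME assay on L6 cells (Rattus norvegicus) for cytotoxicity, read by resazurin assay, with a stated time of 72 h (on this read-out lower numbers stand for stronger inhibition and higher numbers for weaker inhibition), compound 1 (`Cc1ccc(C(O)(c2ccc(Cl)cc2)c2cccnc2)cc1`) reads 61000 nM and compound 2 (`OC(c1ccc(Cl)cc1)(c1cccnc1)c1ccccc1Br`) reads 55200 nM on the two numbers available, so these compounds stand within the scatter of each other. Among the measured compounds shown here, the single measured step is a 1.1-fold lower number from compound 1 to compound 2 (0.04 log units; within the scatter) and it puts 2-bromophenyl in place of 4-methylphenyl on a saturated chain carbon bound to two aromatic carbons and an oxygen on a saturated carbon.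

Compound 3 (`OC(c1ccc(Cl)cc1)(c1cccnc1)c1cccc(Br)c1`) is unmeasured and differs from compound 2 as follows: 3-bromophenyl in place of 2-bromophenyl on a saturated chain carbon bound to two aromatic carbons and an oxygen on a saturated carbon with the same atoms joined differently. For the measured compounds named here, no measured pair yet tests the position of the bromine, so the evidence is indirect. The size of a 1.1-fold lower number from compound 1 to compound 2 (0.04 log units; within the scatter) gives no ground for expecting a shift beyond the scatter, and no direction can be argued from it. The expected change is a 1.0-fold lower number from compound 2 to compound 3 (0.01 log units; within the scatter) and it is estimated to remain within the scatter. For compound 3 the estimated value in this assay is 54000 nM with an expected range of 27000 nM to 100000 nM around it.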

Compound 3, half-maximal inhibitory concentration: 54100 nM
Compound 3: the middle estimate sits 1.0-fold (0.00 log units) below what was measured; low and high end bracket the measured number.
By their numbers in this assay, from the lowest: compounds 3, 2 and 1 (each within the scatter of the next).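

In this assay, among the compounds shown here, the first direct comparison of the bromine's position gives a 1.0-fold lower number from compound 2 to compound 3 (0.01 log units; within the scatter) for 3-bromophenyl in place of 2-bromophenyl on a saturated chain carbon bound to two aromatic carbons and an oxygen on a saturated carbon, so these two placements of the bromine are not separated on this read-out. The step from the methyl-bearing group to the new isomer gives a 1.1-fold lower number from compound 1 to compound 3 (0.05 log units; within the scatter) and, with the earlier step, places all three compounds within the scatter of one another, so neither change shown at this place separates them. No evidence on hand bears on the reason for this flat response.

Going by these compounds, whether an amine or a carboxylic acid on the phenyl ring at this place would move the number beyond the scatter remains open, as does the effect of such groups on the other aromatic groups of the shared core. Also open, on these data alone, is how much the oxygen on the saturated carbon contributes, a question that a methoxy group or an amine there would address.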